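The source may report more compounds than this note shows. Statements on the series, on what has been measured and on what is new or still open speak of the compounds shown alone.

Measured in an ADME assay on NHDF cells (Homo sapiens) for cytotoxicity, read by MTT assay, with a stated time of 72 h; on this read-out higher numbers stand for weaker inhibition and lower numbers for stronger inhibition:
- compound 1 `COc1ccc(/C=C2\CCC/C(=C\c3cccc(OC)c3OC)C2=O)cc1OC`: 14900 nM
- compound 2 `COc1ccc(/C=C2\CCC/C(=C\c3ccccc3Cl)C2=O)cc1OC`: 21600 nM
- compound 3 `COc1ccc(/C=C2\CCC/C(=C\c3cccc(Br)c3)C2=O)cc1OC`: 12400 nM

Compound 3, at 12400 nM, lies within the scatter of both compound 1 and compound 2, so the three values form a single narrow group.

The next compound to be read is compound 4 `COc1ccccc1/C=C1\CCC/C(=C\c2ccc(OC)c(OC)c2)C1=O`. The change is 2-methoxyphenyl in place of 3-bromophenyl on a double-bonded chain carbon bound to a double-bonded ring carbon, with 2-methoxyphenyl in place of 3-bromophenyl on a double-bonded chain carbon bound to a double-bonded ring carbon.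

Among the measured compounds shown here, the one measured step at this place is a 1.7-fold lower number from compound 2 to compound 3 (0.24 log units; within the scatter), and it stays within the scatter. Compound 1, which also carries methoxy groups on the ring at this place, gives 14900 nM. For the measured compounds named here, the data hold no compound with 2-methoxyphenyl itself, so the expectation rests on this narrow spread alone.

No step beyond the scatter is therefore expected in this assay. The expected step is a 1.2-fold higher number from compound 3 to compound 4 (0.08 log units; within the scatter). Compound 4 is estimated at 15000 nM, with an expected range of 8000 nM to 28000 nM.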

Compound 4, half-maximal inhibitory concentration: 18100 nM
Beside the measured number, compound 4's estimate is 1.2-fold (0.08 log units) below it; the range from low to high includes it.
By their numbers in this assay, from the lowest: compounds 3, 1, 4 and 2 (each within the scatter of the next).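

In this assay, 2-methoxyphenyl in place of 3-bromophenyl on a double-bonded chain carbon bound to a double-bonded ring carbon gives a 1.5-fold higher number from compound 3 to compound 4 (0.16 log units; within the scatter), so this place accepts a methoxy-bearing ring without a step beyond the scatter. The two finer changes at this place read the same way: methoxy in place of chloro gives a 1.2-fold lower number from compound 2 to compound 4 (0.08 log units; within the scatter), and hydrogen in place of methoxy gives a 1.2-fold higher number from compound 1 to compound 4 (0.08 log units; within the scatter). All four compounds thus stay within a flat stretch at this place, and nothing on hand offers an explanation for that flatness.

Going by these compounds, whether an amine or a carboxylic acid on this aromatic ring would produce a step beyond the scatter stays open. So does the effect of a longer chain or a saturated ring in place of the aromatic ring.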